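Benzyloxy for bromo on a twin-chalcone scaffold

A few compounds are considered here, and "the series" means these few. Any claim that something is new, unique, unknown or untested is made for them only; others in the source may bear on it.

The series rests on one shared core carrying two enone arms. Compound 1 `Cc1cc(O)c(C(=O)/C=C/c2ccc(F)cc2)c(-c2ccccc2)c1C(=O)/C=C/c1ccc(F)cc1` bears fluoro on each arm and, in a functional assay on HeLa cells (Homo sapiens) for cytotoxicity, read by MTT assay, with a stated time of 24 h (a higher number here means a weaker inhibitor, a lower number a stronger inhibitor), compound 1 gives 30000 nM. Compound 2 `Cc1cc(O)c(C(=O)/C=C/c2ccccc2)c(-c2ccccc2)c1C(=O)/C=C/c1ccccc1` carries unsubstituted arms and in this assay compound 2 is recorded as "not active" (no number reported). Compound 3 `COc1ccc(/C=C/C(=O)c2c(C)cc(O)c(C(=O)/C=C/c3ccc(OC)cc3)c2-c2ccc(Br)cc2)cc1` pairs methoxy arms with bromo on the pendant ring, and in this assay compound 3 likewise stands as "not active" (no number reported), so it has no number of its own, only the note that it did not inhibit. Compound 4 `COc1ccc(/C=C/C(=O)c2c(C)cc(O)c(C(=O)/C=C/c3ccc(OC)cc3)c2-c2ccc(OCc3ccccc3)cc2)cc1` is the next compound: benzyloxy in place of bromo on an aromatic carbon. Among the measured compounds shown here, no measured pair in this set shows what such a change does, and among the compounds that do carry a number only compound 1 offers any anchor, itself weak. For the measured compounds named here, with compound 3 giving no number, he expects no step in this assay beyond the scatter, and most likely another report of no activity. Compound 4 is estimated at 40000 nM, within 15000 nM to 100000 nM.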

Compound 4, half-maximal inhibitory concentration: 28000 nM
Compound 4: middle estimate off by 1.4-fold (0.15 log units), on the high side; the measured number falls inside the stated range.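

In this assay, among the compounds shown here, compound 3 carries no number, and no step from it to compound 4 can be read. The compounds shown leave open what benzyloxy in place of bromo does to this activity. No measurement shown here accounts for the value of compound 4.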